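Methoxycarbonyl to carboxy: a clearance question for compound 3

A few compounds are considered here, and "the series" means these few. Any claim that something is new, unique, unknown or untested is made for them only; others in the source may bear on it.

Among the measured compounds shown here, in an ADME assay on the whole organism (Rattus norvegicus, strain Sprague-Dawley) for pharmacokinetics, read by LC-MS, with a stated time of 48 h, at a dose of 3 mg/kg by the intravenous route (on this read-out higher numbers stand for fast clearance and lower numbers for slow clearance), compound 2 (`CC#CCn1c(N2CCC[C@@H](N)C2)cc(=O)n(Cc2ccc(F)c(C(=O)OC)c2)c1=O`) gives 3 mL/min/kg, the lowest of the two numbers so far. Compound 1 (`CC#CCn1c(N2CCC[C@@H](N)C2)cc(=O)n(Cc2ccc(Cl)c(C(=O)O)c2)c1=O`) gives 64.8 mL/min/kg, a much higher number and well beyond the usual scatter of repeated measurements. Compound 3 (`CC#CCn1c(N2CCC[C@@H](N)C2)cc(=O)n(Cc2ccc(F)c(C(=O)O)c2)c1=O`) has not yet been measured. It differs from compound 2 in one place, with hydrogen in place of methyl on an oxygen next to a carbonyl group, so that methoxycarbonyl becomes carboxy (hydrogen in place of methyl on an oxygen next to a carbonyl group). For the measured compounds named here, no measured pair shows this change on its own, so any expectation here is indirect. Going by the values given here, the only guide is that compound 1 also carries a carboxy group and gives 64.8 mL/min/kg, although it is not identical to compound 3 elsewhere. On that single comparison, the expected change is a 15-fold higher number from compound 2 to compound 3 (1.18 log units; beyond the scatter), towards faster clearance and beyond the scatter. For compound 3 the estimated clearance is 45 mL/min/kg, with an expected range from 18 mL/min/kg to 90 mL/min/kg.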

Compound 3, clearance: 93.7 mL/min/kg
For compound 3 the middle estimate is 2.1-fold (0.32 log units) below the measured one, and the stated range ends below it.
By their numbers in this assay, from the lowest: compound 2; then compounds 1 and 3 (each within the scatter of the next).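

In this assay the change from methoxycarbonyl to carboxy gives a 31-fold higher number from compound 2 to compound 3 (1.49 log units; beyond the scatter), so swapping hydrogen for methyl on an oxygen next to a carbonyl group now has a directly measured effect, and that effect is large. A single hydrogen in place of a single methyl is enough to separate the slowest-clearing compound shown from the other two. The second step, fluoro in place of chloro on an aromatic carbon, gives a 1.4-fold higher number from compound 1 to compound 3 (0.16 log units; within the scatter) and shows that, with carboxy present, this halogen swap cannot be told apart from the ordinary spread of repeated measurements, but no measurement shown here accounts for the large shift seen with the first change.

Going by these compounds, it remains open whether the same large step would appear with chloro rather than fluoro on the aromatic carbon, since the step has been read only in the fluoro pair. Also open, on these data alone, is where other groups in this place would fall on the clearance scale, for example ethoxycarbonyl, with its longer chain, or a primary amide.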